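A few compounds are considered here, and "the series" means these few. Any claim that something is new, unique, unknown or untested is made for them only; others in the source may bear on it.

In an ADME assay on Akata cells (Homo sapiens) for cytotoxicity (a lower number here means that less compound is tolerated, a higher number that more compound is tolerated), compound 2 `Nc1nc2c(ncn2/C=C2/C[C@@H]2[C@@H](O)CO)c(=O)[nH]1` gives 56000 nM and stands within the scatter of compound 1 `Nc1ncnc2c1ncn2/C=C1/C[C@H]1[C@H](O)CO` at 93500 nM and of compound 3 `Nc1ncnc2c1ncn2/C=C1\C[C@H]1[C@@H](O)CO` at 73000 nM with no order among them. Compound 4 `Nc1nc2c(ncn2/C=C2\C[C@H]2[C@H](O)CO)c(=O)[nH]1` is still unmeasured, and the change from compound 2 is the two compounds have the same atoms and bonds and differ only in configuration as drawn: 3 of 3 stereo elements differ; a stereocentre at a saturated ring carbon is drawn S in compound 2 and R in compound 4; a stereocentre at a saturated chain carbon is drawn R in compound 2 and S in compound 4; a double bond is drawn Z in compound 2 and E in compound 4 with nothing leaving or entering. Bearing on this are the fact that compounds 1 and 3 differ only in the configuration as drawn and the step of a 1.3-fold lower number from compound 1 to compound 3 (0.11 log units; within the scatter) which stays within the scatter. On these data alone, that step leaves the ring stereocentre untouched, so this element remains untested. No change beyond the scatter is expected, and no firm direction. The expected move is a 1.1-fold higher number from compound 2 to compound 4 (0.03 log units; within the scatter) and it is a small one. For compound 4 the estimate is 60000 nM with an expected range from 30000 nM to 115000 nM in this series.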

Compound 4, half-maximal cytotoxic concentration: 86600 nM
Estimate against measurement, compound 4: 1.4-fold (0.16 log units) below; measured number inside the range.
By their numbers in this assay, from the lowest: compounds 2, 3, 4 and 1 (each within the scatter of the next).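

In this assay, changing all three stereo elements at once, including the stereocentre at the saturated ring carbon that the earlier pair left untouched, gives a 1.5-fold higher number from compound 2 to compound 4 (0.19 log units; within the scatter). Configuration as drawn has now produced no step beyond the scatter in either pair, and this second pair extends that reading to the compounds carrying the carbonyl on the core: the fact that compounds 2 and 4 differ only in the configuration as drawn

The three elements changed together, so the contribution of each alone cannot be read. On these data alone, whether a carboxylic acid or a longer chain on the shared core would give a step beyond the scatter remains open.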